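The source may report more compounds than this note shows. Statements on the series, on what has been measured and on what is new or still open speak of the compounds shown alone.

Working notes on the series. The shared core of compound 1 `COc1ccc(C(=O)/C=C/c2cc(-c3ccc(OC)c(OC)c3)n3nc(-c4ccccc4)cc3n2)cc1` carries a 3,4-dimethoxyphenyl and a phenyl in all three measured compounds; in a functional assay on DU-145 cells (Homo sapiens) for antiproliferative activity, read by MTT assay, with a stated time of 24 h (on this read-out higher numbers stand for weaker inhibition and lower numbers for stronger inhibition), compound 1 gives 14600 nM. Compound 2 `COc1ccc(-c2cc(/C=C/C(=O)c3ccccc3)nc3cc(-c4ccccc4)nn23)cc1OC` gives 10000 nM, and compound 3 `COc1ccc(/C=C/C(=O)c2cc(-c3ccc(OC)c(OC)c3)n3nc(-c4ccccc4)cc3n2)cc1` gives 14900 nM. Compound 3 holds the highest of the three numbers, yet every gap to it sits within the scatter: a 1.0-fold higher number from compound 1 to compound 3 (0.01 log units; within the scatter) and a 1.5-fold higher number from compound 2 to compound 3 (0.17 log units; within the scatter). Compound 4 `COc1ccc(-c2cc(C(=O)/C=C/c3ccccc3)nc3cc(-c4ccccc4)nn23)cc1OC` differs from compound 3 in one place: hydrogen in place of methoxy on an aromatic carbon. Going by the values given here, the one measured step of the same kind, a 1.5-fold lower number from compound 1 to compound 2 (0.16 log units; within the scatter), lies within the scatter, and the exchange of enone direction, a 1.0-fold higher number from compound 1 to compound 3 (0.01 log units; within the scatter), also left the number essentially unchanged. Nothing in these three compounds therefore points to a step beyond the scatter in this assay, in either direction. Compound 4 is expected to land close to compound 3, with a 1.2-fold lower number from compound 3 to compound 4 (0.09 log units; within the scatter) as the implied step. The estimate for compound 4 is 12000 nM, with a range from 5500 nM to 27000 nM.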

Compound 4, half-maximal inhibitory concentration: 15600 nM
Compound 4: the middle estimate sits 1.3-fold (0.11 log units) below what was measured; measured number inside the range.
By their numbers in this assay, from the lowest: compounds 2, 1, 3 and 4 (each within the scatter of the next).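

Hydrogen in place of methoxy at this position, para to a large group, has now been read on both enone orientations in this assay, and neither reading goes beyond the scatter: the same change on two cores in this assay, a 1.5-fold lower number (0.16 log units; within the scatter) from compound 1 to compound 2 and a 1.0-fold higher number (0.02 log units; within the scatter) from compound 3 to compound 4, 1.5-fold (0.18 log units) apart, within the scatter of two such steps

The new reading, a 1.0-fold higher number from compound 3 to compound 4 (0.02 log units; within the scatter), turns the (2-(4-methoxyphenyl)ethenyl)carbonyl group into (2-phenylethenyl)carbonyl and shows that the earlier flat step was not confined to the one core. The remaining comparisons, a 1.6-fold higher number from compound 2 to compound 4 (0.19 log units; within the scatter) and a 1.1-fold higher number from compound 1 to compound 4 (0.03 log units; within the scatter), also stay within the scatter, so these four compounds show no separation from either change.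

On these data alone, whether any other group at this position would move the number beyond the scatter stays open, for instance an amine, a carboxylic acid or a longer chain such as butoxy in place of methoxy. As far as these compounds go, the 3,4-dimethoxyphenyl and phenyl groups are common to all four compounds, so their part in the numbers also stays open.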